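This account rests on a few compounds, and the source may have more. Where it says the series, first, only, none or still open, it means among the compounds named here.

Of the compounds shown here, three from this series have been measured in an assay on HL-60 cells for inhibition of glutathione S-transferase P (Homo sapiens), read by spectrophotometry, tested at 20 uM; on this read-out higher numbers stand for more inhibition at the one concentration tested (going by the name of the read-out) and lower numbers for less inhibition. Compound 1 `COc1cc(/C=C2\CN(CC(=O)O)c3c(C)cccc3C2=O)cc(OC)c1` gives 32.3%, compound 2 `Cc1cccc2c1N(CC(=O)O)C/C(=C\c1ccccc1Cl)C2=O` gives 51.9%, and compound 3 `COc1ccc(/C=C2\CN(CC(=O)O)c3c(Cl)cccc3C2=O)c(OC)c1OC` gives 23.6%. Among these three numbers compound 2 stands highest: compound 1 is its nearest neighbour, lower by a margin beyond the scatter, and compound 3 lies furthest, also beyond the scatter. Compound 4 `Cc1cccc2c1N(CC(=O)O)C/C(=C\c1ccc(F)cc1)C2=O` has not yet been measured in this assay. It differs from compound 2 in one place: 4-fluorophenyl in place of 2-chlorophenyl on a double-bonded chain carbon bound to a double-bonded ring carbon. Among the measured compounds shown here, no measured pair in the set shows this particular change, so its size cannot be read from a recorded step. The two compounds that carry phenyl groups bearing methoxy substituents, compound 1 and compound 3, give lower inhibition than compound 2, which suggests that the result is sensitive to what sits on this ring. A moderate decrease is therefore expected from compound 2 to compound 4, of about a number 11.9 percentage points lower from compound 2 to compound 4 (beyond the scatter). Compound 4 is estimated at 40%, between 25% and 55%.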

Compound 4, a percentage reported as inhibition, at one concentration (the size of the read-out at that concentration, not a potency): 22.9%
Beside the measured number, compound 4's estimate is 17.1 percentage points above it; the measured number lies below the stated range.
By their numbers in this assay, from the lowest: compounds 4, 3 and 1 (each within the scatter of the next); then compound 2.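

In this assay, among the compounds shown here, 4-fluorophenyl in place of 2-chlorophenyl on a double-bonded chain carbon bound to a double-bonded ring carbon gives a number 29 percentage points lower from compound 2 to compound 4 (beyond the scatter), the only step recorded at this position, and it shows that the read-out responds to a change on this ring while the rest of the structure stays fixed. The two groups have the same counts of heavy atoms, hydrogen-bond donors and hydrogen-bond acceptors, so those counts do not separate them, yet the change swaps the halogen and moves it at once. No measurement available here gives a reason for the step.

Going by these compounds, whether the identity of the halogen or its place on the ring matters more remains open. On these data alone, how a plain phenyl group, or a phenyl group bearing an amine or a carboxylic acid, would read here is also open.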